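This account rests on a few compounds, and the source may have more. Where it says the series, first, only, none or still open, it means among the compounds named here.

Three members of the series have numbers in an assay on isolated protein (Oryctolagus cuniculus) for inhibition of Calpain-2 catalytic subunit (Homo sapiens), at pH 8.0; a lower number here means a stronger inhibitor, a higher number a weaker inhibitor. Among the compounds with values here, compound 1 `CCC(NC(=O)C(CC(C)C)NC(=O)OCc1ccccc1)C(=O)C(=O)NCC1CCCCC1` gives 44 nM in this assay, and compound 2 `CCC(NC(=O)C(CC(C)C)NC(=O)OCc1ccccc1)C(=O)C(=O)NCc1ccccc1` gives 22 nM; the one paired change measured so far is a 2.0-fold lower number from compound 1 to compound 2 (0.30 log units; within the scatter). Compound 3 `CCCC(NC(=O)C(CC(C)C)NC(=O)OCc1ccccc1)C(=O)C(N)=O` gives 78 nM in this assay, the highest of the three numbers: against compound 1 it sits within the scatter, against compound 2 beyond it.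

Compound 4 `CCC(NC(=O)C(CC(C)C)NC(=O)OCc1ccccc1)C(=O)C(=O)O` has not been measured. Relative to compound 3 the change is a group of 8 heavy atoms (5 carbon, 3 oxygen; no ring) in place of a group of 9 heavy atoms (6 carbon, 1 nitrogen, 2 oxygen; no ring), on an amide-type nitrogen whose other neighbour is a carbonyl carbon. Within the data shown here, no measured step touches this part of the shared core; the single step on record alters a different part of the structure and was within the scatter, so it gives no guide to direction or size here. With nothing in the series to anchor the change, the expectation for compound 4 is a somewhat higher number in this assay, a 2.6-fold higher number from compound 3 to compound 4 (0.41 log units; beyond the scatter), carrying a wide range. Compound 4 is estimated at 200 nM in this assay, between 50 nM and 800 nM.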

Compound 4, inhibition constant: 22 nM
The estimate for compound 4 lay 9.1-fold (0.96 log units) above the measured number, outside the stated range (below it).
By their numbers in this assay, from the lowest: compounds 2, 4, 1 and 3 (each within the scatter of the next, the first and the last beyond it).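

Within the data shown here, on the amide-type nitrogen whose other neighbour is a carbonyl carbon, the 8-heavy-atom group in place of 1-(carbamoylcarbonyl)butyl gives a 3.5-fold lower number from compound 3 to compound 4 (0.55 log units; beyond the scatter) in this assay and is the only step at this position, so this part of the core does respond to change. On the carbonyl carbon, hydroxy in place of benzylamino gives no change at the digits printed from compound 2 to compound 4 (within the scatter) and hydroxy in place of (cyclohexylmethyl)amino gives a 2.0-fold lower number from compound 1 to compound 4 (0.30 log units; within the scatter) in this assay, so these three end groups are not told apart here and neither ring-bearing amino group is required for a number in this range. Nothing available bears on the reason for either result.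

As far as these compounds go, the step on the nitrogen alters the chain and its end group together, so the share of each stays open; a 1-(carbamoylcarbonyl)propyl group on the same nitrogen would separate them. From the compounds shown here alone, it is also open whether a methyl ester or a morpholine amide on the carbonyl carbon would stay within the scatter of hydroxy.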